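The source may hold more compounds than are shown below. What is called first, only, known or untested is meant among the compounds shown, and "the series" means these compounds.

Compound 1 `CCN(CC)c1ccc(-n2cc(-c3ccc(C)c(Nc4nccc(-c5cccnc5)n4)c3)nn2)cc1` gives in a functional assay on K562 cells (Homo sapiens) for inhibition, read by MTT assay, with a stated time of 72 h (a higher number here means a weaker inhibitor, a lower number a stronger inhibitor), only a limit, > 30000 nM. Compound 2 `Cc1ccc(-c2nnc(-c3ccc(CN4CCN(C)CC4)cc3)o2)cc1Nc1nccc(-c2cccnc2)n1` gives in this assay 4900 nM. Compound 3 `Cc1ccc(-c2nnc(-c3ccc(CN4CCN(C)CC4)c(C(F)(F)F)c3)o2)cc1Nc1nccc(-c2cccnc2)n1` gives in this assay 510 nM, the lowest of the two numbers, reached by the step of a 9.6-fold lower number from compound 2 to compound 3 (0.98 log units; beyond the scatter). Compound 4 `Cc1ccc(-c2nnc(-c3ccc(CN4CCN(CCN)CC4)c(C(F)(F)F)c3)o2)cc1Nc1nccc(-c2cccnc2)n1` differs from compound 3 by aminomethyl in place of hydrogen on a saturated chain carbon bound to an amine nitrogen in a ring. For the measured compounds named here, no measured step touches this place; the one measured step, a 9.6-fold lower number from compound 2 to compound 3 (0.98 log units; beyond the scatter), changes the aromatic carbon and not the ring amine chain, so it carries no weight here. The change is therefore expected to give no step beyond the scatter in this assay, the estimated step being a 1.0-fold lower number from compound 3 to compound 4 (0.01 log units; within the scatter). Compound 4 is expected to come in at 500 nM, between 150 nM and 1700 nM.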

Compound 4, half-maximal inhibitory concentration: 300 nM
For compound 4 the middle estimate is 1.7-fold (0.22 log units) above the measured one, within the range that was stated.
By their numbers in this assay, from the lowest: compounds 4 and 3 (each within the scatter of the next); then compound 2. At a limit, above all of these: compound 1.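

Replacing methyl with 2-aminoethyl, the first change shown at this place, gives a 1.7-fold lower number from compound 3 to compound 4 (0.23 log units; within the scatter) in this assay. The saturated chain carbon bound to an amine nitrogen in a ring therefore takes an added aminomethyl with no step beyond the scatter, and compound 3 and compound 4 stand level. Nothing measured here bears on a cause for this result.

As far as these compounds go, whether a carboxylic acid, a hydroxyl or a longer chain in place of 2-aminoethyl would keep the number there remains open. Also open, from the compounds shown here alone, is whether 2-aminoethyl behaves alike without the trifluoromethyl.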